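Swapping the Hydrazone Aryl Group for a Styryl Arm

The compounds below may be only part of what the source reports. "The series", "measured", "known", "first", "only" and "open" are said of these compounds alone.

Measured compounds:
compound 1 `O=C(CSc1nnc(-c2ccncc2)n1-c1ccccc1)N/N=C/c1ccc(O)cc1`: in a functional assay on MCF7 cells (Homo sapiens) for inhibition, read by MTT assay, with a stated time of 48 h (a higher number here means a weaker inhibitor, a lower number a stronger inhibitor), compound 1 gives > 50000 nM, which is a limit of the assay and not a number.
compound 2 `O=C(CSc1nnc(-c2ccncc2)n1-c1ccccc1)N/N=C/c1cc(Br)cc(Br)c1O`: in this assay compound 2 gives 8440 nM.

Compound 2 is the only one of the two with a measured number; the other value shown is a limit, as noted in the limit of > 50000 nM in this assay, at which 1 of the 2 values shown sits. For the measured compounds named here, the single measured step, an at least 5.9-fold lower number from compound 1 to compound 2 (0.77 log units; beyond the scatter), shows that the dibrominated hydroxyphenyl brought the value from a limit down to a number.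

Compound 3 `O=C(CSc1nnc(-c2ccncc2)n1-c1ccccc1)N/N=C/C=C/c1ccccc1` differs from compound 2 as follows: 2-phenylethenyl in place of 3,5-dibromo-2-hydroxyphenyl on a carbon with a double bond to nitrogen. Going by the values given here, no measured step covers this change, since the one step measured exchanges one hydroxyphenyl for another, whereas here the aromatic ring moves one double bond away from the hydrazone carbon and the hydroxyl and bromines are lost. Because the only gain recorded, an at least 5.9-fold lower number from compound 1 to compound 2 (0.77 log units; beyond the scatter), came with the dibrominated hydroxyphenyl that is now removed, a weaker inhibitor is expected, with the step of a 3.6-fold higher number from compound 2 to compound 3 (0.55 log units; beyond the scatter) estimated to be modest and upward. Compound 3 is therefore estimated to give about 30000 nM, within a range of 8000 nM to 100000 nM, with a real chance that only a limit is reported.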

Compound 3, half-maximal inhibitory concentration: 11200 nM
Compound 3: middle estimate off by 2.7-fold (0.43 log units), on the high side; low and high end bracket the measured number.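

The change to 2-phenylethenyl gives a 1.3-fold higher number from compound 2 to compound 3 (0.12 log units; within the scatter), so in this assay compound 2 and compound 3 cannot be told apart, although the entering group holds carbon only and the leaving group carries two bromines and a hydroxyl. The bromines and the hydroxyl are therefore not required on this carbon with a double bond to nitrogen for a measured number to appear, as an at least 4.4-fold lower number from compound 1 to compound 3 (0.64 log units; beyond the scatter) shows that a quite different group also stands clear of 4-hydroxyphenyl. Compound 1 gives a limit and not a number, so the true size of that step stays unknown: the limit of > 50000 nM in this assay, at which 1 of the 3 values shown sits.

Still open, from the compounds shown here alone, is whether the two active groups share a feature or merely both avoid something about 4-hydroxyphenyl, a question that a plain phenyl or a 2-hydroxyphenyl without bromine on the same carbon would help to answer. Also open, going by these compounds, is whether this position can yield a clearly stronger inhibitor at all, for instance with a longer chain such as 4-phenylbuta-1,3-dienyl or with an amine such as 4-(dimethylamino)phenyl.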